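This account rests on a few compounds, and the source may have more. Where it says the series, first, only, none or still open, it means among the compounds named here.

In an ADME assay on HEK293 cells (Homo sapiens) for cytotoxicity, with a stated time of 6 h (a lower number here means that less compound is tolerated, a higher number that more compound is tolerated), compound 1 (`CNc1nc(N)nc2ccccc12`) reads > 25000 nM as a limit and not a number. Compound 2 (`CCCCNc1nc(N)nc2ccc(F)cc12`) also stands only at a limit, > 18000 nM in this assay and no number. Compound 3 (`CCCCNc1nc(N)nc2ccc(CO)cc12`) has hydroxymethyl in place of fluoro on an aromatic carbon. Among the compounds with values here, no measured step sizes this change, so no shift beyond the usual scatter is expected in this assay and another limit is the likeliest report. The expected move is a step that the limit leaves unreadable from compound 2 to compound 3 and remains only an estimate. Compound 3 is estimated at 25000 nM with an expected range from 10000 nM to 60000 nM in this series.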

Compound 3, half-maximal cytotoxic concentration: > 18000 nM
Compound 3: no number, only a limit; the forecaster's own chance of this, stated with the estimate: 75%; the middle value is on the limit's open side.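

Within the data shown here, compound 2 and compound 3 stand only at limits, so no step between them can be read: the limit of > 18000 nM in this assay, at which 2 of the 3 values shown sit. The compounds shown leave open where any true value lies in this assay, and whether hydroxymethyl in place of fluoro on an aromatic carbon shifts it.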